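The compounds below may be only part of what the source reports. "The series", "measured", "known", "first", "only" and "open" are said of these compounds alone.

Series notes, amide-type nitrogen on the shared core.

Compound 1 `NNC(=O)c1c(NC(=O)NS(=O)(=O)c2ccccc2)sc2c1CCCCC2` carries amino on the amide-type nitrogen; in a functional assay on UACC-257 cells (Homo sapiens) for inhibition, with a stated time of 48 h (on this read-out lower numbers stand for stronger inhibition of growth and higher numbers for weaker inhibition of growth), compound 1 gives 2800 nM. Compound 2 `CCCNC(=O)c1c(NC(=O)NS(=O)(=O)c2ccccc2)sc2c1CCCCC2` carries propyl at the same place. In this assay compound 2 gives only the limit > 100000 nM, so for compound 2 no number stands, only a limit. Going by the values given here, the one measured step, an at least 35-fold higher number from compound 1 to compound 2 (1.55 log units; beyond the scatter), is therefore an underestimate of what the change from amino to propyl costs, its size being bounded by the limit of > 100000 nM in this assay, at which 1 of the 2 values shown sits.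

Compound 3 `O=C(Nc1sc2c(c1C(=O)NNc1ccc(Br)cc1)CCCCC2)NS(=O)(=O)c1ccccc1` is the next member; it differs from compound 2 by (4-bromophenyl)amino in place of propyl on an amide-type nitrogen. The change restores a nitrogen bearing a hydrogen on the amide-type nitrogen, as in compound 1, while adding the ring. Among the compounds with values here, the only step that bears on it is the step from compound 1 to compound 2, which shows that removing the amino and putting propyl there costs a large amount; the reverse direction is expected to recover much of it, so a large drop in number is expected for compound 3, an at least 16-fold lower number from compound 2 to compound 3 (1.22 log units; beyond the scatter). Compound 3 is estimated at 6000 nM, between 1200 nM and 60000 nM.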

Compound 3, concentration for 50% growth inhibition: > 100000 nM
Compound 3: a limit, no number (the forecaster's own chance of this, stated with the estimate: 25%); middle value at least 16-fold (1.22 log units) away from the limit.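

In this assay, 4-bromophenyl in place of hydrogen on the amine nitrogen gives an at least 35-fold higher number from compound 1 to compound 3 (1.55 log units; beyond the scatter), so a nitrogen bearing a hydrogen on the amide-type nitrogen does not by itself keep the growth inhibition seen with compound 1. Compound 2 and compound 3 both stand only as limits, whatever sits on the amide-type nitrogen, and the step between them cannot be read. Of the three compounds, only compound 1 gives a number, and the size of each large step is bounded: the limit of > 100000 nM in this assay, at which 2 of the 3 values shown sit.

The compounds shown do not tell whether the loss from amino to (4-bromophenyl)amino goes with the aromatic ring or with the bromine, a question that an unsubstituted phenyl or a methyl on the amine nitrogen would help to separate. Nor do they tell whether a shorter chain such as methyl or ethyl on the amide-type nitrogen, with no amino there, keeps any of the inhibition that compound 1 shows at 2800 nM.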